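The compounds below may be only part of what the source reports. "The series", "measured", "known", "first", "only" and "open" are said of these compounds alone.

Compound 1 `N#CC1=C(N)Oc2c(N)cc3nc4ccccc4nc3c2C12C(=O)N(Cc1cnnn1-c1ccc(Cl)cc1)c1ccccc12`: in a functional assay on HepG2 cells (Homo sapiens) for antiproliferative activity, read by MTT assay, with a stated time of 48 h (on this read-out higher numbers stand for weaker inhibition and lower numbers for stronger inhibition), compound 1 gives > 50000 nM, which is a limit of the assay.
Compound 2 `N#CC1=C(N)Oc2c(N)cc3nc4ccccc4nc3c2C12C(=O)N(Cc1cnnn1-c1cccc(Br)c1)c1ccccc12`: in this assay compound 2 gives > 50000 nM, again a limit.
Compound 3 `COc1ccc(-n2nncc2CN2C(=O)C3(C(C#N)=C(N)Oc4c(N)cc5nc6ccccc6nc5c43)c3ccccc32)cc1`: in this assay compound 3 gives > 50000 nM, also a limit.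

Compound 3 therefore stands only at a limit, and the same holds for the two other measured compounds, all three sitting at the one boundary (the limit of > 50000 nM in this assay, at which 3 of the 3 values shown sit). None of the changes among them can be read: the step that the two limits leave unreadable from compound 1 to compound 2, the step that the two limits leave unreadable from compound 1 to compound 3 and the step that the two limits leave unreadable from compound 2 to compound 3 are each hidden by the limits on both sides.

Compound 4 `COc1ccccc1-n1nncc1CN1C(=O)C2(C(C#N)=C(N)Oc3c(N)cc4nc5ccccc5nc4c32)c2ccccc21` is the next member. It differs from compound 3 by 2-methoxyphenyl in place of 4-methoxyphenyl on an aromatic nitrogen. Among the compounds with values here, the measured steps bear on this change only in that each of them also reshuffles the substituent on the same aromatic nitrogen, and each of them was unreadable; there is no measured step that resolves a number anywhere.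

On that basis compound 4 is expected to stay at the limit as well, with the step that the limit leaves unreadable from compound 3 to compound 4 expected to be none readable. The estimate for compound 4 in this assay is 60000 nM, with a range from 20000 nM to 200000 nM.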

Compound 4, half-maximal inhibitory concentration: > 50000 nM
Compound 4 ended at the assay's limit (the forecaster's own chance of this, stated with the estimate: 85%); the middle value is on the limit's open side.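

Compound 4 also stands at a limit in this assay, so none of its steps from compound 1, compound 2 or compound 3 can be read, and all the compounds share one boundary: the limit of > 50000 nM in this assay, at which 4 of the 4 values shown sit.
The compounds shown leave open whether any substituent on the aromatic nitrogen of this shared core gives a measurable value in this read-out.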